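The source may hold more compounds than are shown below. What is called first, only, known or untested is meant among the compounds shown, and "the series" means these compounds.

Measured in an ADME assay on CHO-K1 cells (Cricetulus griseus) for activation, read by fluorescence, tested at 10 uM; on this read-out lower numbers stand for a stronger effect and higher numbers for a weaker effect at the one concentration tested:
compound 1, `COc1cc(/C=C/C(=O)/C=C(/C=C/c2ccc(O)c(OC)c2)NCCO)ccc1O`, 90.9%
compound 2, `COCCNC(=C\C(=O)/C=C/c1ccc(O)cc1)/C=C/c1ccc(O)cc1`, 75.1%
compound 3, `COCCCNC(=C\C(=O)/C=C/c1ccc(O)cc1)/C=C/c1ccc(O)cc1`, 97%

Compound 3 stands at the highest number of the three in this assay, that is, at the weakest effect of the set. Its gap to compound 1 lies within the scatter; its gap to compound 2 is beyond it, a number 21.9 percentage points higher from compound 2 to compound 3 (beyond the scatter). Among the measured compounds shown here, that step, methoxymethyl in place of methoxy on a saturated chain carbon two bonds from the amine nitrogen, is the only measured step.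

Compound 4, `O=C(/C=C(/C=C/c1ccc(O)cc1)NCCCO)/C=C/c1ccc(O)cc1`, is compound 3 with hydrogen in place of methyl on an oxygen on a saturated carbon. For the measured compounds named here, no measured step covers this exchange. The step from compound 2 to compound 3 concerns the chain on the same arm, not the oxygen substituent, and gives no direction for a methyl-to-hydrogen exchange. Compound 1 carries a chain ending in a free hydroxyl, on a different core, and in this assay compound 1 gives 90.9%, within the scatter of compound 3.

Going by the values given here, with compound 3 already at the weak end of the read-out and no bearing step, the expectation for compound 4 is no step beyond the scatter, a number 5 percentage points lower from compound 3 to compound 4 (within the scatter). Compound 4 is estimated at 92%, expected range 80% to 102%.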

Compound 4, a percentage reported as activity, at one concentration (the size of the read-out at that concentration, not a potency): 80.5%
Compound 4: the middle estimate sits 11.5 percentage points above what was measured; measured number inside the range.
By their numbers in this assay, from the lowest: compounds 2 and 4 (each within the scatter of the next); then compounds 1 and 3 (each within the scatter of the next).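

In this assay, methyl and hydrogen on an oxygen on a saturated carbon do not read alike on this arm (a number 16.5 percentage points lower from compound 3 to compound 4 (beyond the scatter)), so the group on that oxygen counts for the number as well as the chain that carries it. The remaining new step gives a much smaller difference (a number 5.4 percentage points higher from compound 2 to compound 4 (within the scatter)), so among the three compounds on the shared core, compound 3 is the one that stands apart, and it does so only with its methyl in place. Nothing at hand gives a measured reason for either step.

Among the compounds shown here, still open is whether the methyl-to-hydrogen step holds on the shorter arm, since the 2-hydroxyethyl chain appears here only on the core of compound 1 and the shared core has no counterpart to compare with compound 2. Also open, from the compounds shown here alone, is how the read-out would respond to an ethyl group on the same oxygen, to an amine or a carboxylic acid at the chain end, or to a longer chain ending in hydroxy.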